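Swapping cyclopropyl for 4-fluorophenyl on two related cores

The source may hold more compounds than are shown below. What is called first, only, known or untested is meant among the compounds shown, and "the series" means these compounds.

Compound 1 `O=C(O)c1cn(C2CC2)c2nc(N3CCC(n4c(=O)[nH]c5cc(Cl)ccc54)CC3)c([N+](=O)[O-])cc2c1=O` and compound 3 `O=C(O)c1cn(-c2ccc(F)cc2)c2nc(N3CCC(n4c(=O)[nH]c5cc(Cl)ccc54)CC3)c([N+](=O)[O-])cc2c1=O` share a core and differ at a single place: 4-fluorophenyl in place of cyclopropyl on an aromatic nitrogen. In an ADME assay on Vero cells (Chlorocebus sabaeus) for cytotoxicity, read by MTT assay, with a stated time of 72 h (a higher number here means a weaker inhibitor, a lower number a stronger inhibitor), compound 1 gives 55500 nM, and compound 3 gives 53900 nM, a step of a 1.0-fold lower number from compound 1 to compound 3 (0.01 log units; within the scatter). Compound 2 `CC(C)(C)NC(=O)C1c2ccccc2CCN1c1nc2c(cc1[N+](=O)[O-])c(=O)c(C(=O)O)cn2C1CC1` rests on a different core; the difference between the two cores is not broken down here. In this assay compound 2 gives 124000 nM, the highest of the three numbers and beyond the scatter from both others. Compound 4 `CC(C)(C)NC(=O)C1c2ccccc2CCN1c1nc2c(cc1[N+](=O)[O-])c(=O)c(C(=O)O)cn2-c1ccc(F)cc1` stands to compound 2 as compound 3 stands to compound 1: 4-fluorophenyl in place of cyclopropyl on an aromatic nitrogen, the same change at the same place. Because the earlier step of a 1.0-fold lower number from compound 1 to compound 3 (0.01 log units; within the scatter) stayed within the scatter, a similarly small step is expected here, a 1.0-fold lower number from compound 2 to compound 4 (0.01 log units; within the scatter). Compound 4 is therefore estimated at 120000 nM, with a likely range from 60000 nM to 240000 nM.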

Compound 4, half-maximal inhibitory concentration: 112000 nM
The estimate for compound 4 lay 1.1-fold (0.03 log units) above the measured number; measured number inside the range.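

In this assay, 4-fluorophenyl in place of cyclopropyl on the aromatic nitrogen gives a 1.1-fold lower number from compound 2 to compound 4 (0.04 log units; within the scatter), and the earlier step on the other core reads the same way: the same change on two cores in this assay, a 1.0-fold lower number (0.01 log units; within the scatter) from compound 1 to compound 3 and a 1.1-fold lower number (0.04 log units; within the scatter) from compound 2 to compound 4, 1.1-fold (0.03 log units) apart, within the scatter of two such steps

So, for these four compounds, the swap carries from one core to the other as a step too small to tell apart from repeat-measurement noise. Among the compounds shown here, this rests on only two cores and one assay, and since neither step is a real shift, it does not show that a sizeable effect of a change would carry over between cores.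

The compounds shown leave open how other groups on that nitrogen would behave, such as an ethyl chain or a phenyl ring carrying an amine. They also leave open whether the swap would stay this small on a third core.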